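Methyl in Place of Trifluoromethyl: Projecting Compound 3

This account rests on a few compounds, and the source may have more. Where it says the series, first, only, none or still open, it means among the compounds named here.

Compound 1, `CC(C(=O)NCc1ccc(Cl)cc1)c1ccc(NS(C)(=O)=O)c(F)c1`, in a functional assay on CHO cells for antagonist activity at transient receptor potential cation channel subfamily V member 1 (Rattus norvegicus); on this read-out higher numbers stand for weaker inhibition and lower numbers for stronger inhibition: 367 nM
Compound 2, `CC(C(=O)NCc1ccc(C(F)(F)F)cc1)c1ccc(NS(C)(=O)=O)c(F)c1`, in this assay : 274 nM

Compound 2 gives the lower of the two numbers, but its separation from compound 1 is small: a 1.3-fold lower number from compound 1 to compound 2 (0.13 log units; within the scatter). The two compounds are therefore not distinguishable on this read-out.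

Compound 3, `Cc1ccc(CNC(=O)C(C)c2ccc(NS(C)(=O)=O)c(F)c2)cc1`, differs from compound 2 by methyl in place of trifluoromethyl on an aromatic carbon. Going by the values given here, no measured step replaces trifluoromethyl with methyl; the only step available, from chloro to trifluoromethyl, stayed within the scatter. The two measured compounds thus suggest that this position tolerates exchange of small groups without a clear shift.

On that basis the step to compound 3 is expected to be modest, a 1.3-fold higher number from compound 2 to compound 3 (0.11 log units; within the scatter), with no firm direction. Compound 3 is estimated at 350 nM in this assay, with a range from 150 nM to 850 nM.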

Compound 3, inhibition constant: 930 nM
Beside the measured number, compound 3's estimate is 2.7-fold (0.42 log units) below it; the whole stated range lies below it.
By their numbers in this assay, from the lowest: compounds 2 and 1 (each within the scatter of the next); then compound 3.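

Chloro and trifluoromethyl had left this aromatic carbon, para to a large group, without a separable difference, so the position had looked open to exchange. Methyl separates from both in this assay, against trifluoromethyl (a 3.4-fold higher number from compound 2 to compound 3 (0.53 log units; beyond the scatter)) and against chloro (a 2.5-fold higher number from compound 1 to compound 3 (0.40 log units; beyond the scatter)), which shows that the group at this position does matter and that both changes lead towards weaker inhibition. Nothing available here accounts for why methyl stands apart from the other two groups.

The compounds shown leave open how other groups on this carbon would read, such as methoxy, a nitrile, an amine or tert-butyl. From the compounds shown here alone, it also remains open whether any group here could give a clearly lower number than chloro and trifluoromethyl do.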